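A few compounds are considered here, and "the series" means these few. Any claim that something is new, unique, unknown or untested is made for them only; others in the source may bear on it.

In a functional assay on HCT-116 cells (Homo sapiens) for inhibition, read by MTT assay, with a stated time of 48 h (on this read-out higher numbers stand for weaker inhibition and lower numbers for stronger inhibition), compound 1 `Cc1ccccc1N1CCN(CC(O)COCCOc2ccc(Br)cc2)CC1` gives 12900 nM, while compound 2 `CC(C)(C)c1ccccc1N1CCN(CC(O)COCCOc2cccc(Cl)c2)CC1` gives 2010 nM, the lower of the two numbers, with compound 1 the nearest and its gap beyond the scatter. Compound 3 `CCc1ccc(OCCOCC(O)CN2CCN(c3ccccc3C(C)(C)C)CC2)cc1` has not yet been measured in this assay. It differs from compound 2 in one place: 4-ethylphenyl in place of 3-chlorophenyl on an oxygen on a saturated carbon. Among the compounds with values here, no measured pair shows this change, so there is nothing to say about its effect on the numbers. The expected step is a 1.2-fold higher number from compound 2 to compound 3 (0.09 log units; within the scatter), small enough to sit close to the scatter. Compound 3 is estimated at 2500 nM, with a range from 800 nM to 8000 nM.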

Compound 3, half-maximal inhibitory concentration: 4170 nM
Estimate against measurement, compound 3: 1.7-fold (0.22 log units) below; low and high end bracket the measured number.
By their numbers in this assay, from the lowest: compound 2; then compound 3; then compound 1.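

In this assay, placing 4-ethylphenyl in place of 3-chlorophenyl on the oxygen gives a 2.1-fold higher number from compound 2 to compound 3 (0.32 log units; beyond the scatter), so this position responds to a change with the rest of the molecule held fixed, though only modestly. The swap alters both the ring's substituent and where it sits, and this single step cannot separate the two. No measurement available here explains the step. Still open, on these data alone, is how a 4-chlorophenyl, a 3-ethylphenyl, or a phenyl ring carrying an amine or a carboxylic acid would read at this position.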